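A few compounds are considered here, and "the series" means these few. Any claim that something is new, unique, unknown or untested is made for them only; others in the source may bear on it.

Three compounds with a shared core were tested in an ADME assay on BJ cells (Homo sapiens) for cytotoxicity, read by CellTiter-Glo and resazurin assay, with a stated time of 72 h; on this read-out lower numbers stand for an effect already at smaller amounts and higher numbers for an effect only at larger amounts of compound. Compound 1 `CC(C)N(Cc1cccc(OCCCCCC(=O)O)c1)C(=O)c1ccc(-c2ccc(Cl)c(Cl)c2)cc1` carries a 3,4-dichlorophenyl group and a free carboxy group. In this assay compound 1 reaches only a limit of the assay, > 26000 nM. Compound 2 `CC(C)N(Cc1cccc(OCCCCCC(=O)O)c1)C(=O)c1ccc(-c2cccc(Cl)c2)cc1` differs from compound 1 by hydrogen in place of chloro on an aromatic carbon. In this assay compound 2 likewise stops at a limit, > 21900 nM. Compound 3 `CCOC(=O)CCCCCOc1cccc(CN(C(=O)c2ccc(-c3ccc(Cl)c(Cl)c3)cc2)C(C)C)c1` differs from compound 1 by ethyl in place of hydrogen on an oxygen next to a carbonyl group. In this assay compound 3 also gives a limit, > 26000 nM. The step that the two limits leave unreadable from compound 1 to compound 2 and the step that the two limits leave unreadable from compound 1 to compound 3 cannot be sized: two of the three values sit at the limit of > 26000 nM in this assay, at which 2 of the 3 values shown sit, and one at the limit of > 21900 nM in this assay, at which 1 of the 3 values shown sits.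

Compound 4 `CCOC(=O)CCCCCOc1cccc(CN(C(=O)c2ccc(-c3cccc(Cl)c3)cc2)C(C)C)c1` is not yet measured. It differs from compound 3 by hydrogen in place of chloro on an aromatic carbon, the same change as that from compound 1 to compound 2, at the same place. Compound 4 is expected to remain at a limit too, with an estimated value of 30000 nM. This expectation rests on compound 2, whose value > 21900 nM is a limit. The step that the limit leaves unreadable from compound 3 to compound 4 is estimated to be negligible.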

Compound 4, half-maximal effective concentration: > 18400 nM
Compound 4 ended at the assay's limit; the forecaster's own chance of this, stated with the estimate: 85%; the middle value lies beyond the limit too.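

In this assay compound 4 gives > 18400 nM, which is a limit. Compound 2 and compound 3 also stop at limits, and no size can be read for the steps linking compound 4 to either of them. The compounds shown leave open at what concentration, if any, these compounds reach a half-maximal effect, and whether either change alters it.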